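The compounds below may be only part of what the source reports. "The series", "measured", "known", "first", "only" and "open" are said of these compounds alone.

In a functional assay on PC-3 cells (Homo sapiens) for cytotoxicity, read by MTT assay, with a stated time of 24 h (a higher number here means a weaker inhibitor, a lower number a stronger inhibitor), compound 2 `Cc1ccc(/C=C2\CN(Cc3cn(Cc4ccc(F)cc4)nn3)C/C(=C\c3ccc(C)cc3)C2=O)cc1` gives 65600 nM. This lies within the usual scatter of compound 3 `Cc1ccc(/C=C2\CN(C(=S)SCc3cn(Cc4ccc(F)cc4)nn3)C/C(=C\c3ccc(C)cc3)C2=O)cc1`, which gives 45500 nM. Compound 1 `COc1ccc(/C=C2\CN(C(=S)SCc3cn(Cc4ccccc4F)nn3)C/C(=C\c3ccc(OC)cc3)C2=O)cc1` gives 31500 nM, a lower number than compound 2 by more than the scatter. Compound 4 `Cc1ccc(/C=C2\CN(Cc3cn(Cc4ccccc4F)nn3)C/C(=C\c3ccc(C)cc3)C2=O)cc1` differs from compound 2 in one group: 2-fluorophenyl in place of 4-fluorophenyl on a saturated chain carbon bound to an aromatic nitrogen. The swap lies on a saturated chain carbon bound to an aromatic nitrogen. Within the data shown here, no two measured compounds differ in one place only, so the data do not show the effect of this change directly. The measured numbers span only a narrow range, so a step within the scatter is expected in this assay, with no clear direction. The expected change, a 1.3-fold lower number from compound 2 to compound 4 (0.12 log units; within the scatter), is small. For compound 4 the estimated value is 50000 nM, with an expected range from 28000 nM to 95000 nM.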

Compound 4, half-maximal inhibitory concentration: 8800 nM
The estimate for compound 4 lay 5.7-fold (0.75 log units) above the measured number, outside the stated range (below it).
By their numbers in this assay, from the lowest: compound 4; then compounds 1, 3 and 2 (each within the scatter of the next, the first and the last beyond it).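

In this assay the swap of 4-fluorobenzyl for 2-fluorobenzyl gives a 7.5-fold lower number from compound 2 to compound 4 (0.87 log units; beyond the scatter) and adds or removes no atoms, so where the fluorine sits on this ring clearly matters. Among these compounds, this is the first comparison of compounds that differ in one place, which the earlier compounds could not provide. No measurement here explains the size of this step.

From the compounds shown here alone, it remains open whether 2-chlorobenzyl or 2-methylbenzyl would match 2-fluorobenzyl here. Going by these compounds, it is also open whether the same swap would give a similar step in compound 3.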